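Methyl on the saturated ring carbon of compound 2

A few compounds are considered here, and "the series" means these few. Any claim that something is new, unique, unknown or untested is made for them only; others in the source may bear on it.

Measured compounds in a functional assay on MDBK cells (Bos taurus) for cytotoxicity; on this read-out lower numbers stand for higher toxicity in this test and higher numbers for lower toxicity in this test:
- compound 1 `Cc1ccc(O)c(C(=O)NCCCCN2[C@H](C)CCC[C@@H]2C)c1`: > 100 ug/mL, a limit of the assay, not a number
- compound 2 `Cc1ccc(O)c(C(=O)NCCCCN2CCC[C@@H]3CCCC[C@@H]32)c1`: 30 ug/mL
- compound 3 `O=C(NCCCN1CCC[C@@H]2CCCC[C@@H]21)c1cc(Cl)ccc1O`: 43 ug/mL

Compound 2 holds the lowest of the two numbers in this assay. The nearest number, that of compound 3 at 43 ug/mL, sits within the scatter of it, so the two show no difference. Compound 1 stands apart in that it reaches only (the limit of > 100 ug/mL in this assay, at which 1 of the 3 values shown sits), which is a limit and not a number.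

Compound 4 `Cc1ccc(O)c(C(=O)NCCCCN2C(C)CC[C@@H]3CCCC[C@@H]32)c1` differs from compound 2 in one place: methyl in place of hydrogen on a saturated ring carbon. The group is small and the rest of the molecule is unchanged. Among the measured compounds shown here, no pair among the measured compounds differs in that kind of place alone, so no measured step gives a size for it. With nothing pointing either way, no step beyond the scatter is expected in this assay from compound 2 to compound 4, while a modest shift toward a higher number cannot be ruled out and is allowed for in the range.

The expected step is a 1.1-fold higher number from compound 2 to compound 4 (0.03 log units; within the scatter), which is estimated to stay within the scatter. Compound 4 is therefore expected at about 32 ug/mL, with a range from 12 ug/mL to 80 ug/mL.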

Compound 4, half-maximal cytotoxic concentration: 90 ug/mL
The estimate for compound 4 lay 2.8-fold (0.45 log units) below the measured number; measured number above the stated range.
By their numbers in this assay, from the lowest: compounds 2 and 3 (each within the scatter of the next); then compound 4. At a limit, above all of these: compound 1.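

In this assay, among the compounds shown here, this is the first measured size for a change at this place: a 3.0-fold higher number from compound 2 to compound 4 (0.48 log units; beyond the scatter). The earlier compounds shown here included no pair differing in one place, so they could not show that a single methyl on a saturated ring carbon next to the ring nitrogen moves the read-out beyond the scatter, here toward lower toxicity in this test, with the rest of the molecule unchanged. Further upward steps at this position can be read only up to the end of the scale: the limit of > 100 ug/mL in this assay, at which 1 of the 4 values shown sits.

All of this rests on one pair, so the compounds shown do not tell whether the step belongs to methyl in particular or would also come with ethyl, hydroxyl or a second methyl on the same carbon, and the structure of compound 4 leaves the configuration at the methyl-bearing carbon unspecified. Also open is whether the same methyl would give a step of like size on the scaffold of compound 3, with its chloro substituent and shorter chain, and nothing shown gives a cause for the step.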